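The source may report more compounds than this note shows. Statements on the series, on what has been measured and on what is new or still open speak of the compounds shown alone.

Measured so far:
compound 1 `CCc1nc(N)nc(N)c1C#CC(C)c1ccc(-c2ccccc2)cc1OC` gives 172 nM
compound 2 `CCc1nc(N)nc(N)c1C#CC(C)c1ccc(-c2ccncc2)cc1OC` gives 127 nM
compound 3 `CCc1nc(N)nc(N)c1C#CC(C)c1ccc(-c2ccc(C#N)cc2)cc1OC` gives 477 nM

Compound 2 shows the lowest number of the three in an assay on isolated protein for inhibition of Dihydrofolate reductase (Homo sapiens), using NADPH, with a stated time of 5 min (a higher number here means a weaker inhibitor, a lower number a stronger inhibitor), yet its step to compound 1, a 1.4-fold lower number from compound 1 to compound 2 (0.13 log units; within the scatter), lies within the scatter, so those two cannot be ordered; only compound 3 stands clearly apart. Compound 4 `CCc1nc(N)nc(N)c1C#CC(C)c1ccc(-c2ccc(C(=O)OC)cc2)cc1OC` differs from compound 2 in one place: 4-(methoxycarbonyl)phenyl in place of pyridin-4-yl on an aromatic carbon. The closest measured step is a 3.8-fold higher number from compound 2 to compound 3 (0.57 log units; beyond the scatter), where a 4-cyanophenyl replaced the pyridin-4-yl; the step of a 2.8-fold higher number from compound 1 to compound 3 (0.44 log units; beyond the scatter) points the same way. Compound 4 is therefore expected to show a modest rise in this assay, a 3.1-fold higher number from compound 2 to compound 4 (0.50 log units; beyond the scatter). The estimate for compound 4 is 400 nM, with a range from 150 nM to 1000 nM.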

Compound 4, half-maximal inhibitory concentration: 49 nM
Compound 4: the middle estimate sits 8.2-fold (0.91 log units) above what was measured, outside the stated range (below it).
By their numbers in this assay, from the lowest: compound 4; then compounds 2 and 1 (each within the scatter of the next); then compound 3.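

At this place on the outer ring, substitution does not push the number in a single direction in this assay: methoxycarbonyl in place of hydrogen gives a 3.5-fold lower number from compound 1 to compound 4 (0.55 log units; beyond the scatter) whereas cyano raised the number. Exchanging the cyano for methoxycarbonyl gives a 9.7-fold lower number from compound 3 to compound 4 (0.99 log units; beyond the scatter) and the change from the pyridin-4-yl compound gives a 2.6-fold lower number from compound 2 to compound 4 (0.41 log units; beyond the scatter) so this ester-bearing ring is clearly preferred over all three earlier groups. Going by these compounds, it remains open whether the carbonyl alone or the whole ester matters, which a carboxylic acid or primary amide here would separate. No measurement shown explains this difference between the ester and the nitrile.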